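The source may report more compounds than this note shows. Statements on the series, on what has been measured and on what is new or still open speak of the compounds shown alone.

Among the measured compounds shown here, compound 1 `Cc1cccc(-c2nc(CNc3ccc(C(=O)NO)cc3)n(-c3ccccc3)n2)c1` is the only compound in this small set with a definite number in a functional assay on MGC-803 cells (Homo sapiens) for antiproliferative activity, read by MTT assay, with a stated time of 72 h; a higher number here means a weaker inhibitor, a lower number a stronger inhibitor: in that assay compound 1 gives 8710 nM. For the measured compounds named here, compound 2 `O=C(NO)c1ccc(NCc2nc(-c3cccs3)nn2-c2ccc(O)cc2)cc1` differs from it in more than one place, so no single step connects the two. In this assay compound 2 reaches only a limit of the assay, > 20000 nM, which is the situation summarised by the limit of > 20000 nM in this assay, at which 1 of the 2 values shown sits. With one number and one limit to hand, compound 1 stands alone as the reference point for anything that follows.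

Compound 3 `COc1ccc(-c2nc(CNc3ccc(C(=O)NO)cc3)n(-c3ccccc3)n2)cc1` has not yet been measured. It departs from compound 1 by a single change: 4-methoxyphenyl in place of 3-methylphenyl on an aromatic carbon. Going by the values given here, no measured pair in the set shows the effect of this kind of change, so there is nothing to suggest a shift in either direction beyond the scatter of this assay. The step of a 1.1-fold lower number from compound 1 to compound 3 (0.04 log units; within the scatter) is expected to be small, within that scatter. Compound 3 is therefore estimated at 8000 nM, with an expected range from 3000 nM to 20000 nM.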

Compound 3, half-maximal inhibitory concentration: > 20000 nM
Compound 3: only a limit was reported; the forecaster's own chance of this, stated with the estimate: 20%; at least 2.5-fold (0.39 log units) between middle value and limit.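

Among the compounds shown here, this is the first single change in the set that can be read. On the aromatic carbon between two ring nitrogen atoms, 4-methoxyphenyl in place of 3-methylphenyl gives an at least 2.2-fold higher number from compound 1 to compound 3 (0.36 log units; beyond the scatter) in this assay, so this position is not indifferent to the group it carries, and swapping one substituted phenyl for another can weaken the antiproliferative effect. The full size of that loss stays unknown, as the result for compound 3 is a limit of the assay and not a number, and compound 1 still holds the only definite value, with most results now at the same limit: the limit of > 20000 nM in this assay, at which 2 of the 3 values shown sit.

The change replaces the methyl group with a methoxy group and also moves the substituent to a different place on the phenyl ring, and the compounds shown do not separate these two parts of the change. Also open, going by these compounds, is how an unsubstituted phenyl group, or a phenyl ring carrying an amine or a carboxylic acid, would read at this position in this assay.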